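Trading trifluoromethoxy for methoxy in a growth inhibitor

This account rests on a few compounds, and the source may have more. Where it says the series, first, only, none or still open, it means among the compounds named here.

Of the compounds shown here, three have been measured in a functional assay on HOP-62 cells (Homo sapiens) for inhibition, read by sulforhodamine B assay; on this read-out lower numbers stand for stronger inhibition of growth and higher numbers for weaker inhibition of growth. Compound 1 `COc1ccc(-c2ccc(-c3ccc(-c4nc5ccccc5[nH]4)cc3)cc2)cc1` gives 100000 nM, compound 2 `Oc1cccc2[nH]c(-c3ccc(-c4ccc(-c5ccccc5)cc4)cc3)nc12` gives 9040 nM, and compound 3 `Oc1cccc2[nH]c(-c3ccc(-c4ccc(-c5ccc(OC(F)(F)F)cc5)cc4)cc3)nc12` gives 2270 nM. Compound 3 thus has the lowest number of the three, and compound 2 is its nearest neighbour.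

Compound 4 `COc1ccc(-c2ccc(-c3ccc(-c4nc5c(O)cccc5[nH]4)cc3)cc2)cc1` has not yet been measured. It differs from compound 3 in one place: methyl in place of trifluoromethyl on an oxygen on an aromatic ring, turning 4-(trifluoromethoxy)phenyl into 4-methoxyphenyl.

For the measured compounds named here, only one measured step bears on this change. It is a 4.0-fold lower number from compound 2 to compound 3 (0.60 log units; beyond the scatter), seen when trifluoromethoxy replaced hydrogen on an aromatic carbon. Going by the values given here, no measured pair compares methoxy directly with trifluoromethoxy, so this is indirect evidence. Compound 4 keeps the oxygen but loses the fluorines, so it may give back part of the gain from the step of a 4.0-fold lower number from compound 2 to compound 3 (0.60 log units; beyond the scatter), without necessarily returning to the level of compound 2. The expected change is a 2.0-fold higher number from compound 3 to compound 4 (0.30 log units; within the scatter), a small rise in the number that may not clear the usual scatter. For compound 4 the estimated value is 4500 nM, with an expected range from 1500 nM to 13000 nM.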

Compound 4, concentration for 50% growth inhibition: 3210 nM
The estimate for compound 4 lay 1.4-fold (0.15 log units) above the measured number; the measured number falls inside the stated range.
By their numbers in this assay, from the lowest: compounds 3 and 4 (each within the scatter of the next); then compound 2; then compound 1.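

Measured directly against each other in this assay, methyl and trifluoromethyl on this oxygen cannot be told apart (a 1.4-fold higher number from compound 3 to compound 4 (0.15 log units; within the scatter)), so in this pair the fluorines are not required for the level of growth inhibition seen with compound 3. For the compounds shown here, the oxygen-bearing group with no fluorine also counts as a gain over hydrogen on the same aromatic carbon (a 2.8-fold lower number from compound 2 to compound 4 (0.45 log units; beyond the scatter)), which means that the earlier step (a 4.0-fold lower number from compound 2 to compound 3 (0.60 log units; beyond the scatter)) is no longer the only sign that a group at this place can lower the number. Going by these compounds alone, compound 4 also provides the first pair that isolates the hydroxy group on the core, and this is the largest of the new steps (a 31-fold lower number from compound 1 to compound 4 (1.49 log units; beyond the scatter)).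

Nothing measured here explains why any of these steps has the size it has.

Going by these compounds, it remains open how an amine, a carboxylic acid or a longer chain such as butoxy would compare in place of the methoxy, and whether the hydroxy step would keep its size with a group other than methoxy at that place.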